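Adding a Methyl Where the Earlier Methyl Changed Little

A few compounds are considered here, and "the series" means these few. Any claim that something is new, unique, unknown or untested is made for them only; others in the source may bear on it.

Compound 1 `COc1ccc(/C=C/C(=O)NS(=O)(=O)c2ccccc2)cc1` is the starting point. In a functional assay on B16-F10 cells (Mus musculus) for antiproliferative activity, read by ELISA and MTT assay, with a stated time of 48 h (a lower number here means a stronger inhibitor, a higher number a weaker inhibitor), compound 1 gives 13.2 ug/mL. Compound 2 `COc1ccc(/C=C/C(=O)NS(=O)(=O)c2ccc(C)cc2)cc1` carries methyl in place of hydrogen on an aromatic carbon; in this assay compound 2 gives 12.2 ug/mL, and the step is a 1.1-fold lower number from compound 1 to compound 2 (0.03 log units; within the scatter). Compound 3 `CN(C)c1ccc(/C=C/C(=O)NS(=O)(=O)c2ccccc2)cc1` differs from compound 1 in its core by dimethylamino in place of methoxy on an aromatic carbon; in this assay compound 3 gives 2.3 ug/mL, a step of a 5.7-fold lower number from compound 1 to compound 3 (0.76 log units; beyond the scatter), and it holds the lowest of the three numbers. Compound 4 `Cc1ccc(S(=O)(=O)NC(=O)/C=C/c2ccc(N(C)C)cc2)cc1` has not yet been measured. It differs from compound 3 by methyl in place of hydrogen on an aromatic carbon, the same change that separates compound 1 from compound 2, placed on an aromatic carbon of a six-membered aromatic ring of carbon only, para to a large group, in both cases. Because the earlier methyl step of a 1.1-fold lower number from compound 1 to compound 2 (0.03 log units; within the scatter) stayed within the scatter, a step of similar size is expected here, namely a 1.0-fold lower number from compound 3 to compound 4 (0.02 log units; within the scatter). Compound 4 is therefore estimated at 2.2 ug/mL, with an expected range from 1.2 ug/mL to 4.5 ug/mL.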

Compound 4, half-maximal inhibitory concentration: 4.3 ug/mL
Beside the measured number, compound 4's estimate is 2.0-fold (0.29 log units) below it; the measured number falls inside the stated range.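

In this assay, the change from phenyl to 4-methylphenyl gives a 1.9-fold higher number from compound 3 to compound 4 (0.27 log units; within the scatter), so this step, like the earlier methyl step, cannot be told apart from the ordinary spread of repeated measurements, and the two steps agree across the two cores: the same change on two cores in this assay, a 1.1-fold lower number (0.03 log units; within the scatter) from compound 1 to compound 2 and a 1.9-fold higher number (0.27 log units; within the scatter) from compound 3 to compound 4, 2.0-fold (0.31 log units) apart, within the scatter of two such steps

Putting dimethylamino in place of methoxy also carries over, giving a 2.8-fold lower number from compound 2 to compound 4 (0.45 log units; beyond the scatter), a step beyond the scatter and in the same direction as the earlier one on the core without the methyl: the same change on two cores in this assay, a 5.7-fold lower number (0.76 log units; beyond the scatter) from compound 1 to compound 3 and a 2.8-fold lower number (0.45 log units; beyond the scatter) from compound 2 to compound 4, 2.0-fold (0.31 log units) apart, within the scatter of two such steps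

This shows that each change behaved alike in the two pairs available in this one cell assay, but two pairs cannot show that either change would do the same on another core, and they do not explain why the numbers move as they do.

The compounds shown leave open whether a chlorine atom or a nitro group in place of the methyl would also leave the number within the scatter. They also leave open whether a primary amine or a longer alkoxy chain in place of dimethylamino would follow the same direction.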